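The source may hold more compounds than are shown below. What is called first, only, known or untested is meant among the compounds shown, and "the series" means these compounds.

Values measured so far in a functional assay on U-87MG ATCC cells (Homo sapiens) for inhibition (a lower number here means a stronger inhibitor, a higher number a weaker inhibitor), are these:
- compound 1 `COc1cc(/C=C/C(=O)c2cccc(NC(=O)c3ccc(Cl)cc3)c2)ccc1O` gives > 50 ug/mL as a limit
- compound 2 `COc1cc(/C=C/C(=O)c2cccc(NC(=O)c3ccco3)c2)ccc1O` gives 6.65 ug/mL as a number
- compound 3 `COc1cc(/C=C/C(=O)c2cccc(NC(=O)c3ccc(Cl)c(Cl)c3)c2)ccc1O` gives 29.5 ug/mL as a number

Compound 3 holds the higher of the two actual numbers in this assay, and compound 2 is its nearest neighbour. Compound 1 is reported only as a limit.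

The next compound is compound 4 `COc1cc(/C=C/C(=O)c2cccc(NC(=O)C(C)C)c2)ccc1O`, with isopropyl in place of 3,4-dichlorophenyl on a carbonyl carbon. Among the measured compounds shown here, no compound measured so far has a group without a ring at this place, so the measured steps bear on the change only indirectly.

Two steps replace the whole group on that carbonyl carbon: an at least 7.5-fold lower number from compound 1 to compound 2 (0.87 log units; beyond the scatter) and a 4.4-fold higher number from compound 2 to compound 3 (0.65 log units; beyond the scatter) are both beyond the scatter and leave compound 2, with furan-2-yl, lowest of the three. The chloro step, an at least 1.6-fold lower number from compound 1 to compound 3 (0.22 log units; that floor lies within the scatter) as its floor, adds little.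

Going by compound 2 in a 4.4-fold higher number from compound 2 to compound 3 (0.65 log units; beyond the scatter) as the only guide, losing 3,4-dichlorophenyl is expected to lower the number modestly, by less than that gap. The expected change is a 2.3-fold lower number from compound 3 to compound 4 (0.36 log units; beyond the scatter) and may not clear the scatter by much. For compound 4 the estimated value is 13 ug/mL with 4 ug/mL to 45 ug/mL as the expected range.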

Compound 4, half-maximal inhibitory concentration: 8.31 ug/mL
Estimate against measurement, compound 4: 1.6-fold (0.19 log units) above; the measured number falls inside the stated range.
By their numbers in this assay, from the lowest: compounds 2 and 4 (each within the scatter of the next); then compound 3. At a limit, above all of these: compound 1.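

In this assay, among the compounds shown here, the earlier compounds all carried a ring on the carbonyl carbon; isopropyl now shows that no ring is needed at this place to reach the level of the furan-2-yl compound, with a 1.2-fold higher number from compound 2 to compound 4 (0.10 log units; within the scatter). Replacing 3,4-dichlorophenyl with isopropyl gives a 3.5-fold lower number from compound 3 to compound 4 (0.55 log units; beyond the scatter), so among the compounds shown the two chlorinated phenyl groups, in compound 1 and compound 3, stand apart from both furan-2-yl and isopropyl, and a ring at this place does not by itself set the number. The step of an at least 6.0-fold lower number from compound 1 to compound 4 (0.77 log units; beyond the scatter) points the same way but gives only a floor, and compound 1 remains a limit: the limit of > 50 ug/mL in this assay, at which 1 of the 4 values shown sits.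

The compounds shown leave open whether the loss of chlorine or the loss of the six-membered aromatic ring matters more, a question that plain phenyl and cyclohexyl on the same carbonyl carbon would address. They also leave open how far a group without a ring can be changed, for example to a longer chain or to a chain ending in an amine or a carboxylic acid.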